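The compounds below may be only part of what the source reports. "The series", "measured", "known", "first", "only" and "open" are said of these compounds alone.

In an ADME assay on BT-549 cells (Homo sapiens) for cytotoxicity, read by neutral red uptake, with a stated time of 48 h (a lower number here means a stronger inhibitor, a higher number a weaker inhibitor), compound 1 `O=c1sc2ccccc2n1CCCCCN1CCN(CCCCCn2c(=O)sc3ccccc32)CC1` gives 19300 nM and compound 2 `O=c1sc2ccccc2n1CCCCCCN1CCN(CCCCn2c(=O)sc3ccccc32)CC1` gives 21300 nM. Compound 2 therefore stands level with compound 1, as the two values lie within the usual scatter. Compound 3 `O=c1sc2ccccc2n1CCCCCCN1CCN(CCCCCn2c(=O)sc3ccccc32)CC1` differs from compound 2 by a single change, (a group of 11 heavy atoms (8 carbon, 1 nitrogen, 1 oxygen, 1 sulfur; one five-membered aromatic ring with 2 hetero atoms, one six-membered aromatic ring of carbon only) in place of a group of 10 heavy atoms (7 carbon, 1 nitrogen, 1 oxygen, 1 sulfur; one five-membered aromatic ring with 2 hetero atoms, one six-membered aromatic ring of carbon only), on a saturated chain carbon, four bonds along the chain from an amine nitrogen in a ring), on a saturated chain carbon, four bonds along the chain from an amine nitrogen in a ring. Within the data shown here, no measured step shows this change. With compound 1 at 19300 nM and compound 2 at 21300 nM, no step beyond the scatter is expected in this assay, in either direction. The estimated step is a 1.1-fold lower number from compound 2 to compound 3 (0.05 log units; within the scatter). For compound 3 the expected value is 19000 nM, with an estimated range of 9500 nM to 38000 nM.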

Compound 3, half-maximal inhibitory concentration: 19600 nM
For compound 3 the middle estimate is 1.0-fold (0.01 log units) below the measured one, within the range that was stated.
By their numbers in this assay, from the lowest: compounds 1, 3 and 2 (each within the scatter of the next).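

In this assay, the group of 11 heavy atoms in place of the group of 10 heavy atoms, on a saturated chain carbon, four bonds along the chain from an amine nitrogen in a ring, gives a 1.1-fold lower number from compound 2 to compound 3 (0.04 log units; within the scatter). The same exchange five bonds along the chain from that nitrogen gives a 1.0-fold higher number from compound 1 to compound 3 (0.01 log units; within the scatter), so at both places it stays within the scatter. Nothing measured here offers an explanation for this. As far as these compounds go, whether a longer chain at these places would step beyond the scatter remains open. So does the effect of a carboxylic acid on the chain.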